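Amide swap in a series sitting at the limit

The compounds below may be only part of what the source reports. "The series", "measured", "known", "first", "only" and "open" are said of these compounds alone.

Measured in a functional assay on MCF7 cells (Homo sapiens) for antiproliferative activity, read by sulforhodamine B assay, with a stated time of 48 h; on this read-out higher numbers stand for weaker inhibition and lower numbers for stronger inhibition:
- compound 1 `CCCCN(C)C(=O)CCCOc1cc(OC)c(OC)c2oc(-c3ccc(OC)cc3)c(O)c(=O)c12` gives > 40000 nM (a limit)
- compound 2 `COc1ccc(-c2oc3c(OC)c(OC)cc(OCCCC(=O)NCc4ccccn4)c3c(=O)c2O)cc1` gives > 40000 nM (a limit)

Compound 2 stands at > 40000 nM, which is a limit and not a number. Among the measured compounds shown here, the series so far shows only (the limit of > 40000 nM in this assay, at which 2 of the 2 values shown sit), so no number anchors it. For the measured compounds named here, the one measured step, a step that the two limits leave unreadable from compound 1 to compound 2, gives no size to carry forward.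

Compound 3 `COc1ccc(-c2oc3c(OC)c(OC)cc(OCCCC(=O)N4CCN(C)CC4)c3c(=O)c2O)cc1` has 4-methylpiperazin-1-yl in place of ((pyridin-2-yl)methyl)amino on a carbonyl carbon. Going by the values given here, no measured step speaks to this change directly. Because of the limit of > 40000 nM in this assay, at which 2 of the 2 values shown sit, compound 3 is expected to stay in the same range as compound 2 in this assay, with no step beyond the scatter and no direction expected. The expected step is a number no higher from compound 2 to compound 3 (the limit leaves the size open) and remains a rough estimate. For compound 3 the estimate is 40000 nM, with an expected range of 15000 nM to 80000 nM, and a report as a limit only is the likeliest outcome.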

Compound 3, half-maximal inhibitory concentration: > 40000 nM
Compound 3: no number, only a limit; the forecaster's own chance of this, stated with the estimate: 75%; the middle value sits exactly at the limit.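

In this assay, among the compounds shown here, compound 3 gives > 40000 nM, a limit and not a number, so no step from compound 1 or compound 2 to compound 3 can be read. Whether any amide on the shared core gives a measurable value in this assay remains open: the limit of > 40000 nM in this assay, at which 3 of the 3 values shown sit.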